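This account rests on a few compounds, and the source may have more. Where it says the series, first, only, none or still open, it means among the compounds named here.

Compound 1 `O=C(NCCO)c1cccc(Nc2ncc(F)c(Nc3ccc(F)cc3)n2)c1`: 12400 nM
Compound 2 `Cn1ccnc1NC(=O)c1cccc(Nc2ncc(F)c(Nc3ccc(F)cc3)n2)c1`: 14600 nM

Both numbers come from a functional assay on KB cells (Homo sapiens) for antiproliferative activity, read by sulforhodamine B assay, with a stated time of 3 days; a lower number here means a stronger inhibitor of growth, a higher number a weaker inhibitor of growth. Within the data shown here, the one step measured so far, a 1.2-fold higher number from compound 1 to compound 2 (0.07 log units; within the scatter), lies within the scatter, so compound 1 cannot be told apart from compound 2 on these numbers. Compound 3 `O=C(Nc1cccc(Nc2ncc(F)c(Nc3ccc(F)cc3)n2)c1)c1cnccn1` differs from compound 1 in one place: ((pyrazin-2-yl)carbonyl)amino in place of (2-hydroxyethyl)carbamoyl on an aromatic carbon. That measured step, a swap on an amide-type nitrogen, does not cover this kind of change, and it was small in any case. In this assay the change from compound 1 to compound 3 is therefore expected to give no step beyond the scatter, roughly a 1.2-fold higher number from compound 1 to compound 3 (0.08 log units; within the scatter). Compound 3 is estimated at 15000 nM, with a range from 5000 nM to 45000 nM.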

Compound 3, concentration for 50% growth inhibition: 23600 nM
Estimate against measurement, compound 3: 1.6-fold (0.20 log units) below; the measured number falls inside the stated range.
By their numbers in this assay, from the lowest: compounds 1, 2 and 3 (each within the scatter of the next).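

In this assay the ((pyrazin-2-yl)carbonyl)amino group on this aromatic carbon replaces two different carbamoyl groups, and neither swap gives a step beyond the scatter (a 1.9-fold higher number from compound 1 to compound 3 (0.28 log units; within the scatter); a 1.6-fold higher number from compound 2 to compound 3 (0.21 log units; within the scatter)). So, among these three compounds, even a group attached through its nitrogen rather than its carbonyl carbon and bearing a six-membered aromatic ring with 2 hetero atoms does not separate the numbers. No available measurement accounts for this result.

On these data alone, whether an amine, a carboxylic acid or a longer chain on this aromatic carbon would give a step beyond the scatter remains open. So does the effect of a plain phenyl ring in place of the pyrazin-2-yl ring.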